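A few compounds are considered here, and "the series" means these few. Any claim that something is new, unique, unknown or untested is made for them only; others in the source may bear on it.

Compound 1, with the structure `CC(C)c1cc(OCC(=O)[C@H](CC(=O)O)NC(=O)[C@@H](NC(=O)COc2cccc3ccccc23)C(C)C)no1`, is measured in a functional assay on Jurkat cells (Homo sapiens) for inhibition; on this read-out lower numbers stand for stronger inhibition and higher numbers for weaker inhibition. In this assay compound 1 gives > 200000 nM, which is a limit of the assay rather than a number. Compound 2, with the structure `CC(C)[C@H](NC(=O)COc1cccc2ccccc12)C(=O)N[C@@H](CC(=O)O)C(=O)COn1nnc2ccccc21`, shares the same core. In this assay compound 2 gives > 200000 nM, again only a limit. For the measured compounds named here, the single measured step between these two, a step that the two limits leave unreadable from compound 1 to compound 2, therefore cannot be read in size or direction. The evidence behind it is the limit of > 200000 nM in this assay, at which 2 of the 2 values shown sit.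

Compound 3, with the structure `Cc1cc(C)nc(SCC(=O)[C@H](CC(=O)O)NC(=O)[C@@H](NC(=O)COc2cccc3ccccc23)C(C)C)n1`, has not yet been measured in this assay. It differs from compound 1 by (4,6-dimethylpyrimidin-2-yl)sulfanyl in place of (5-isopropyl-1,2-oxazol-3-yl)oxy on a saturated chain carbon bound to a carbonyl carbon. Going by the values given here, no measured step covers this change, and the one step that exists is unreadable, so nothing here points to a gain or a loss beyond the scatter. For compound 3, this means an expected step of a number no higher from compound 1 to compound 3 (the limit leaves the size open). Compound 3 is therefore expected to sit near the same limit, with an estimate of 200000 nM and a range from 50000 nM to 800000 nM.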

Compound 3, half-maximal inhibitory concentration: > 200000 nM
Compound 3: no number, only a limit (the forecaster's own chance of this, stated with the estimate: 80%); the middle value sits exactly at the limit.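

In this assay compound 3 gives > 200000 nM, which is a limit of the assay and not a number. The steps to compound 3 from compound 1 and from compound 2 therefore cannot be read in size or direction. The compounds shown leave open whether any group on that saturated chain carbon gives a measurable inhibition: the limit of > 200000 nM in this assay, at which 3 of the 3 values shown sit.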